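This account rests on a few compounds, and the source may have more. Where it says the series, first, only, none or still open, it means among the compounds named here.

Within the data shown here, compound 3 `COc1cc(Cl)cc(-c2nn(-c3cccc(NC(=O)Nc4cccc(C(F)(F)F)c4)c3)cc2-c2ccncc2)c1` gives, in a functional assay on MOLT-4 cells (Homo sapiens) for inhibition, read by sulforhodamine B assay, with a stated time of 48 h, tested at 0.1 uM (on this read-out lower numbers stand for a stronger effect and higher numbers for a weaker effect at the one concentration tested), 55%, the lowest of the three numbers so far, although compound 1 `COc1cc(Cl)cc(-c2nn(-c3cccc(NC(=O)Nc4ccc(Cl)c(C(F)(F)F)c4)c3)cc2-c2ccncc2)c1` sits within the scatter of it with 57%, while compound 2 `COc1cc(Cl)cc(-c2nn(-c3cccc(NC(=O)Nc4ccc(Cl)c(Cl)c4)c3)cc2-c2ccncc2)c1` gives 88%. Compound 4 `COc1cc(Cl)cc(-c2nn(-c3cccc(NC(=O)c4cccc(C(F)(F)F)c4)c3)cc2-c2ccncc2)c1` differs from compound 3 by 3-(trifluoromethyl)phenyl in place of (3-(trifluoromethyl)phenyl)amino on a carbonyl carbon. Among the measured compounds shown here, none of the measured steps touches this carbonyl part: a number 2 percentage points lower from compound 1 to compound 3 (within the scatter), a number 31 percentage points higher from compound 1 to compound 2 (beyond the scatter) and a number 33 percentage points lower from compound 2 to compound 3 (beyond the scatter) all exchange groups on the outer aromatic ring, leaving the carbonyl carbon and its amide-type nitrogen unchanged. The effect of removing that amino link is not shown anywhere in these data, so the expectation rests on little. For compound 4 the expected step is a number 11 percentage points higher from compound 3 to compound 4 (beyond the scatter), a modestly higher number. Compound 4 is therefore estimated at 66%, within a range of 45% to 90%.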

Compound 4, a percentage reported as activity, at one concentration (the size of the read-out at that concentration, not a potency): 95%
Compound 4: the middle estimate sits 29 percentage points below what was measured; the whole stated range lies below it.
By their numbers in this assay, from the lowest: compounds 3 and 1 (each within the scatter of the next); then compounds 2 and 4 (each within the scatter of the next).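

In this assay, the amino link on the carbonyl carbon proves to matter: exchanging (3-(trifluoromethyl)phenyl)amino for 3-(trifluoromethyl)phenyl gives a number 40 percentage points higher from compound 3 to compound 4 (beyond the scatter), the first change shown at this link rather than on the outer ring. The other two steps, a number 38 percentage points higher from compound 1 to compound 4 (beyond the scatter) and a number 7 percentage points higher from compound 2 to compound 4 (within the scatter), also alter the outer ring, so they say less about the link alone. Nothing available explains why the link matters. From the compounds shown here alone, it remains open whether a methylene group or an ether oxygen in place of the amino nitrogen would keep the lower number.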